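Working notes: from compound 3 to compound 4

The compounds below may be only part of what the source reports. "The series", "measured", "known", "first", "only" and "open" are said of these compounds alone.

Measured in a functional assay on HeLa cells (Homo sapiens) for inhibition, read by MTT assay, with a stated time of 72 h (on this read-out lower numbers stand for stronger inhibition and higher numbers for weaker inhibition), as follows
compound 1 `COc1cc(OC)c(OC)cc1/C=C/C(=O)c1ccc(Cl)cc1` gives 36500 nM
compound 2 `COc1ccc(C(=O)/C=C/c2cc(OC)c(OC)cc2OC)cc1` gives 37600 nM
compound 3 `COc1cc(OC)c(OC)cc1/C=C/C(=O)c1cc(Cl)ccc1O` gives > 150000 nM as a limit

Compound 3 has only a limit (> 150000 nM) and no number, and it is the weakest of the three measured compounds. Compound 4 `COc1cc(OC)c(OC)cc1/C=C/C(=O)c1ccc(C)cc1` differs from compound 3 in one place (4-methylphenyl in place of 5-chloro-2-hydroxyphenyl on a carbonyl carbon) and carries 4-methylphenyl on the carbonyl carbon.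

Going by the values given here, two measured steps bear directly on this change. They are an at least 4.1-fold higher number from compound 1 to compound 3 (0.61 log units; beyond the scatter) and an at least 3.9-fold higher number from compound 2 to compound 3 (0.60 log units; beyond the scatter) and both end at compound 3, with 5-chloro-2-hydroxyphenyl in place of 4-chlorophenyl or 4-methoxyphenyl. The change to compound 4 runs the other way, away from 5-chloro-2-hydroxyphenyl. The third step is a 1.0-fold higher number from compound 1 to compound 2 (0.01 log units; within the scatter) with methoxy in place of chloro, so these two groups do not separate compound 1 from compound 2.

A step to a lower number is therefore expected in this assay with a size similar to those two steps or larger. The level to expect is set by compound 1 (36500 nM) and compound 2 (37600 nM). The expected step is an at least 4.0-fold lower number from compound 3 to compound 4 (0.60 log units; beyond the scatter) as estimated here. For compound 4 the estimated value is 37000 nM with an expected range from 15000 nM to 85000 nM in this read-out.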

Compound 4, half-maximal inhibitory concentration: 42200 nM
Beside the measured number, compound 4's estimate is 1.1-fold (0.06 log units) below it; the range from low to high includes it.
By their numbers in this assay, from the lowest: compounds 1, 2 and 4 (each within the scatter of the next). At a limit, above all of these: compound 3.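

In this assay, the step of an at least 3.5-fold lower number from compound 3 to compound 4 (0.55 log units; beyond the scatter) adds a third group at this place, and it points the same way as the two earlier steps that ended at compound 3, now with a 4-methylphenyl that has only carbon atoms and 0 hydrogen-bond donors or acceptors. The steps of a 1.1-fold higher number from compound 2 to compound 4 (0.05 log units; within the scatter) and a 1.2-fold higher number from compound 1 to compound 4 (0.06 log units; within the scatter) both lie within the scatter, so methyl, methoxy and chloro on that aromatic carbon are not separated in this read-out, and the three compounds that carry them form one level that 5-chloro-2-hydroxyphenyl alone leaves. Compound 3 has a limit and not a number, so the first step gives only a minimum size: the limit of > 150000 nM in this assay, at which 1 of the 4 values shown sits.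

The compounds shown do not tell whether the hydroxyl or the placement of the chlorine within 5-chloro-2-hydroxyphenyl goes with the weaker result, as both differ together in every step to compound 3. Going by these compounds, it also remains open whether a group of another kind on that aromatic carbon, such as an amine or a carboxylic acid, would stay at this level or leave it.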